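This account rests on a few compounds, and the source may have more. Where it says the series, first, only, none or still open, it means among the compounds named here.

Compound 1, `CNc1nc(Nc2ccc(C)c([N+](=O)[O-])c2)ncc1C(=O)Nc1cc(NC(=O)c2cccc(OC)c2)ccc1C`, gives 6310 nM in an ADME assay on BaF3 cells (Mus musculus) for antiproliferative activity, read by CellTiter-Glo and CCK-8 assay, with a stated time of 72 h; a higher number here means a weaker inhibitor of growth, a lower number a stronger inhibitor of growth.
Compound 2, `CNc1nc(Nc2ccc(C)c([N+](=O)[O-])c2)ncc1C(=O)Nc1cc(NC(=O)c2ccc(OC)c(OC)c2)ccc1C`, gives 7300 nM in this assay.
Compound 3, `CNc1nc(Nc2ccc(C)c(N)c2)ncc1C(=O)Nc1cc(NC(=O)c2cc(OC)cc(OC)c2)ccc1C`, gives only a limit of the assay, > 10000 nM, in this assay.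

Compound 2 differs from compound 1 by methoxy in place of hydrogen on an aromatic carbon. The step of a 1.2-fold higher number from compound 1 to compound 2 (0.06 log units; within the scatter). The difference between the core of compound 1 and the core of compound 3 is not broken down here. The value of compound 3 is a limit of the assay and not a number.

Compound 4, `CNc1nc(Nc2ccc(C)c(N)c2)ncc1C(=O)Nc1cc(NC(=O)c2cc(OC)c(OC)c(OC)c2)ccc1C`, is not yet measured. It differs from compound 3 by methoxy in place of hydrogen on an aromatic carbon. This is the same kind of change as that from compound 1 to compound 2, but the place is not the same: in compound 4 the entering methoxy sits ortho to two methoxy groups, in compound 2 ortho to a methoxy group. The expected step is a step that the limit leaves unreadable from compound 3 to compound 4, set beside a 1.2-fold higher number from compound 1 to compound 2 (0.06 log units; within the scatter), and it rests on that measured step together with the fact that compound 3 already sits at the limit of > 10000 nM in this assay, at which 1 of the 3 values shown sits. Compound 4 is therefore estimated at 15000 nM, with a range from 6000 nM to 40000 nM, and most likely another limit.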

Compound 4, concentration for 50% growth inhibition: > 10000 nM
Compound 4 gave a limit, no number; the forecaster's own chance of this, stated with the estimate: 70%; the middle value does not contradict the limit.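

Among the compounds shown here, compound 3 and compound 4 both stop at a limit of the assay, so no step between them can be read: the limit of > 10000 nM in this assay, at which 2 of the 4 values shown sit.
The compounds shown leave open whether in this assay the methoxy that enters in compound 4 changes growth inhibition at all, and how far past the limit either compound lies.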